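Swapping nitro for sulfamoyl on a fused core

This account rests on a few compounds, and the source may have more. Where it says the series, first, only, none or still open, it means among the compounds named here.

Three compounds with a shared fused core were tested in a functional assay on the whole organism (strain Wistar albino) for inhibition, with Rattus norvegicus as the target, read by paw edema, with a stated time of 3 h, at a dose of 25 mg/kg by the oral route; a lower number here means less inhibition, a higher number more inhibition at the dose given (going by the name of the read-out). Compound 1 `CSc1nn(-c2ccc([N+](=O)[O-])cc2)c2nc(Nc3ccccc3)n(-c3ccccc3)c(=O)c12` gives 26.6%. Compound 2 `CSc1nn(-c2ccc(S(N)(=O)=O)cc2)c2nc(Nc3ccccc3)n(-c3ccccc3)c(=O)c12` differs from compound 1 by sulfamoyl in place of nitro on an aromatic carbon, and in this assay compound 2 gives 35.2%, a step of a number 8.6 percentage points higher from compound 1 to compound 2 (within the scatter). Compound 3 `O=c1c2c(Nc3ccc(Cl)cc3)nn(-c3ccc([N+](=O)[O-])cc3)c2nc(Nc2ccccc2)n1-c1ccccc1` differs from compound 1 by (4-chlorophenyl)amino in place of methylsulfanyl on an aromatic carbon; in this assay compound 3 gives 20.6%, a step of a number 6 percentage points lower from compound 1 to compound 3 (within the scatter).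

Compound 4 `NS(=O)(=O)c1ccc(-n2nc(Nc3ccc(Cl)cc3)c3c(=O)n(-c4ccccc4)c(Nc4ccccc4)nc32)cc1` has not yet been measured. It differs from compound 3 by sulfamoyl in place of nitro on an aromatic carbon, and since the place is described in the same words as for the pair of compound 1 and compound 2, this is the same change seen once already. Going by the values given here, from compound 3 to compound 4 the expected step is a number 8.4 percentage points higher from compound 3 to compound 4 (within the scatter), beside the measured step of a number 8.6 percentage points higher from compound 1 to compound 2 (within the scatter), and this expectation rests on that single earlier step because a number 8.6 percentage points higher from compound 1 to compound 2 (within the scatter) is the only observed instance of this change. Compound 4 is therefore estimated to give 29% in this assay, with a plausible range from 18% to 40%.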

Compound 4, a percentage reported as inhibition, in the whole organism at one dose (the size of the read-out at that dose, not a potency): 38.3%
The estimate for compound 4 lay 9.3 percentage points below the measured number; measured number inside the range.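

In this assay, sulfamoyl in place of nitro on the core carrying (4-chlorophenyl)amino gives a step of a number 17.7 percentage points higher from compound 3 to compound 4 (beyond the scatter), and this step agrees with the earlier one on the core carrying methylsulfanyl: the same change on two cores in this assay, a number 8.6 percentage points higher (within the scatter) from compound 1 to compound 2 and a number 17.7 percentage points higher (beyond the scatter) from compound 3 to compound 4, 9.1 percentage points apart, within the scatter of two such steps. The other change, (4-chlorophenyl)amino in place of methylsulfanyl, now seen with sulfamoyl on the aromatic ring, gives a step of a number 3.1 percentage points higher from compound 2 to compound 4 (within the scatter), and it also agrees with its earlier counterpart: the same change on two cores in this assay, a number 6 percentage points lower (within the scatter) from compound 1 to compound 3 and a number 3.1 percentage points higher (within the scatter) from compound 2 to compound 4, 9.1 percentage points apart, within the scatter of two such steps. So both changes carry from one core to the other as far as these four compounds can tell, but two pairs at a single dose cannot show that a step keeps exactly the same size, and they give no rule for any other core.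

From the compounds shown here alone, what a carboxylic acid or an amine would give in the place of nitro and sulfamoyl remains open. The compounds shown also leave open how these numbers would look at other doses or times.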